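The source may hold more compounds than are shown below. What is called first, only, known or untested is meant among the compounds shown, and "the series" means these compounds.

Measured compounds:
Compound 1, `COc1cc(C)cc(-c2c(-c3ccnc(-c4ccc(C(C)=O)cc4)c3)cnn2CC#N)c1`, gives 88% in a functional assay on RPMI8266 cells (Homo sapiens) for cytotoxicity, read by sulforhodamine B assay, with a stated time of 48 h, tested at 100 nM; a lower number here means a stronger effect, a higher number a weaker effect of the compound at the concentration tested.
Compound 2, `Cc1cc(O)cc(-c2nn(CC#N)cc2-c2ccnc(-c3ccc(Oc4ccccc4)cc3)c2)c1`, gives 88% in this assay.
Compound 3, `Cc1cc(O)cc(-c2nn(CC#N)cc2-c2ccnc(-c3ccc(N(C)C)cc3)c2)c1`, gives 96% in this assay.

Compound 1 stands level with compound 2 at the digits shown, and compound 3 lies only a little higher; all three numbers sit within the usual scatter of one another, so no ranking among them can be read from these data.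

Compound 4, `COc1cc(C)cc(-c2c(-c3ccnc(-c4ccc(N(C)C)cc4)c3)cnn2CC#N)c1`, differs from compound 1 in one place: dimethylamino in place of acetyl on an aromatic carbon.

Among the measured compounds shown here, only one measured step speaks to this change. From compound 2 to compound 3 a dimethylamino group replaces a phenoxy group on an aromatic carbon, and a number 8 percentage points higher from compound 2 to compound 3 (within the scatter) shows that this left the read-out within the scatter. The group that leaves here, acetyl, is not the same as phenoxy, so the comparison is loose, but nothing in the data points to a shift beyond the scatter.

Compound 4 is therefore expected to give about 92% in this assay, with a range of 80% to 100%, which means an expected step of a number 4 percentage points higher from compound 1 to compound 4 (within the scatter).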

Compound 4, a percentage reported as activity, at one concentration (the size of the read-out at that concentration, not a potency): 13%
Compound 4: middle estimate off by 79 percentage points, on the high side; the whole stated range lies above it.
By their numbers in this assay, from the lowest: compound 4; then compounds 1, 2 and 3 (each within the scatter of the next).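

In this assay, the change from 4-acetylphenyl to 4-(dimethylamino)phenyl brings a number 75 percentage points lower from compound 1 to compound 4 (beyond the scatter), so this one position can decide whether a compound shows a strong effect at the concentration tested. The same dimethylamino group entering in place of phenoxy brought only a number 8 percentage points higher from compound 2 to compound 3 (within the scatter), so its arrival does not by itself predict the outcome: the result depends on the group that leaves, on the rest of the compound, or on both, and these two steps cannot separate those possibilities. Nothing measured here offers an explanation for the large step.

From the compounds shown here alone, it remains open whether the nitrogen or its two methyl groups matter, which a plain amino group, a diethylamino group or a morpholine ring at this position would help to show. Going by these compounds, it is also open whether the step holds at other concentrations.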